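The source may hold more compounds than are shown below. What is called first, only, known or untested is meant among the compounds shown, and "the series" means these compounds.

Notes on the group on sulfur. In a functional assay on HT cells (Homo sapiens) for antiproliferative activity, read by fluorescence, with a stated time of 72 h (a higher number here means a weaker inhibitor of growth, a lower number a stronger inhibitor of growth), compound 1 (`CC(C)c1n[nH]c2c(NCc3ccc(-c4ccccn4)cc3)nc(SCCO)nc12`) gives 48 nM and compound 2 (`CSc1nc(NCc2ccc(-c3ccccn3)cc2)c2[nH]nc(C(C)C)c2n1`) gives 783 nM which is a 16-fold higher number from compound 1 to compound 2 (1.21 log units; beyond the scatter) overall. Compound 3 (`CC(C)c1n[nH]c2c(NCc3ccc(-c4ccccn4)cc3)nc(SC(C)C(C)O)nc12`) at 190 nM stands second highest of the three, with a 4.0-fold higher number from compound 1 to compound 3 (0.60 log units; beyond the scatter) on one side and a 4.1-fold lower number from compound 2 to compound 3 (0.62 log units; beyond the scatter) on the other. Compound 4 (`CC(C)c1n[nH]c2c(NCc3ccc(-c4ccccn4)cc3)nc(SC3CCCC3O)nc12`) carries 2-hydroxycyclopentyl in place of 2-hydroxy-1-methylpropyl on a sulfur and no ring in this place has a measured value. The two modest steps to compound 3 bear most closely. Compound 4 keeps a hydroxy group as compound 3 at 190 nM does, so no large move toward compound 2 at 783 nM is expected. The expected change is a 1.4-fold lower number from compound 3 to compound 4 (0.13 log units; within the scatter) in this assay and this is a slight shift toward a lower number, not expected to pass the scatter. For compound 4 the estimate is 140 nM with an expected range of 45 nM to 420 nM in this read-out.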

Compound 4, concentration for 50% growth inhibition: 567 nM
Compound 4: middle estimate off by 4.1-fold (0.61 log units), on the low side; the whole stated range lies below it.
By their numbers in this assay, from the lowest: compound 1; then compound 3; then compounds 4 and 2 (each within the scatter of the next).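

In this assay a hydroxy group on the sulfur does not by itself keep the gain over methyl: 2-hydroxycyclopentyl gives a 3.0-fold higher number from compound 3 to compound 4 (0.47 log units; beyond the scatter) and a 12-fold higher number from compound 1 to compound 4 (1.07 log units; beyond the scatter) while a 1.4-fold lower number from compound 2 to compound 4 (0.14 log units; within the scatter) marks no separation from the methyl compound. Compound 1 and compound 3, both open-chain, do stand apart from methyl, so among these hydroxy groups the ring is the exception. Nothing available explains this loss.

Open, as far as these compounds go, is whether an amine or a carboxylic acid in place of the hydroxy group would fare better on the open chain. Also open, from the compounds shown here alone, is what a longer chain carrying the hydroxy group would give.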